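The source may report more compounds than this note shows. Statements on the series, on what has been measured and on what is new or still open speak of the compounds shown alone.

Compound 1, `CCNc1cc(-c2ccc(NC(=O)Nc3ccc(OC)cc3)cc2C(F)(F)F)ccn1`: 62.1%
Compound 2, `CCNc1cc(-c2ccc(NC(=O)Nc3cccc4ccccc34)cc2C(F)(F)F)ccn1`: 54.1%

In an assay on isolated protein for inhibition of serine/threonine-protein kinase PLK1 (Homo sapiens), read by radiometric assay and 33P incorporation, with a stated time of 40 min, tested at 20 uM, in the presence of a further agent that is not named here (on this read-out lower numbers stand for less inhibition and higher numbers for more inhibition at the one concentration tested (going by the name of the read-out)), compound 2 gives 54.1%, while compound 1 gives 62.1%; the step of a number 8 percentage points lower from compound 1 to compound 2 (within the scatter) is within the scatter, so the two compounds stand on a level. Compound 3, `CCNc1cc(-c2ccc(NC(=O)Nc3c(C)cccc3C)cc2C(F)(F)F)ccn1`, carries 2,6-dimethylphenyl in place of naphthalen-1-yl on an amide-type nitrogen. Among the compounds with values here, the only measured step that bears on this exchange is the one on the same amide-type nitrogen, a number 8 percentage points lower from compound 1 to compound 2 (within the scatter), which stayed within the scatter. Compound 3 is therefore expected to show no step beyond the scatter, a number 0.9 percentage points higher from compound 2 to compound 3 (within the scatter). The estimated value of compound 3 in this assay is 55%, in the range 38% to 72%.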

Compound 3, a percentage reported as inhibition, at one concentration (the size of the read-out at that concentration, not a potency): 59.2%
Compound 3: middle estimate off by 4.2 percentage points, on the low side, within the range that was stated.
By their numbers in this assay, from the lowest: compounds 2, 3 and 1 (each within the scatter of the next).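

In this assay, 2,6-dimethylphenyl in place of naphthalen-1-yl gives a number 5.1 percentage points higher from compound 2 to compound 3 (within the scatter), and in place of 4-methoxyphenyl it gives a number 2.9 percentage points lower from compound 1 to compound 3 (within the scatter). With this third aryl group, which has one six-membered aromatic ring rather than two, all three compounds stand on a level, so no exchange at this amide-type nitrogen has yet produced a step beyond the scatter. Nothing at hand explains this level reading. As far as these compounds go, whether an aliphatic amine or a carboxylic acid on this nitrogen would move the number beyond the scatter stays open. So does the effect of any change elsewhere on the shared core.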